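Methoxy for Isopropyl on the Anilino Arm

The source may report more compounds than this note shows. Statements on the series, on what has been measured and on what is new or still open speak of the compounds shown alone.

For the measured compounds named here, compound 2 `COc1cc(/C=C/c2nc(Nc3ccc(C(C)C)cc3)c3sccc3n2)cc(OC)c1OC` is the only compound with a number in a functional assay on L02 cells (Homo sapiens) for inhibition, read by Griess assay, with stated times of 1 h and 24 h (a higher number here means a weaker inhibitor, a lower number a stronger inhibitor), where compound 2 gives 370000 nM. Compound 1 `CCN1CCN(c2nc(/C=C/c3cc(OC)c(OC)c(OC)c3)nc3ccsc23)CC1` reaches only a limit of this assay, > 1000000 nM. Going by the values given here, the one measured step, an at least 2.7-fold lower number from compound 1 to compound 2 (0.43 log units; beyond the scatter), is bounded by the limit in the limit of > 1000000 nM in this assay, at which 1 of the 2 values shown sits, and exchanges the whole amine on the shared core; it says nothing about a swap on the anilino ring itself. Compound 3 `COc1ccc(Nc2nc(/C=C/c3cc(OC)c(OC)c(OC)c3)nc3ccsc23)cc1` differs from compound 2 by methoxy in place of isopropyl on an aromatic carbon. Among the compounds with values here, no measured step bears on this change, so no step beyond the scatter is expected, a 1.1-fold higher number from compound 2 to compound 3 (0.03 log units; within the scatter). Compound 3 is therefore estimated at 400000 nM, within 150000 nM to 1000000 nM.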

Compound 3, half-maximal inhibitory concentration: 279000 nM
For compound 3 the middle estimate is 1.4-fold (0.16 log units) above the measured one, within the range that was stated.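

In this assay, methoxy in place of isopropyl on this aromatic carbon gives a 1.3-fold lower number from compound 2 to compound 3 (0.12 log units; within the scatter), so this exchange on the anilino ring cannot be told from the scatter. With (4-methoxyphenyl)amino in place of 4-ethylpiperazin-1-yl the result is an at least 3.5-fold lower number from compound 1 to compound 3 (0.55 log units; beyond the scatter), so two anilino arms, not one, now stand beyond the scatter from the piperazine compound. That step is open-ended, and compound 1 stands at a limit of the assay: the limit of > 1000000 nM in this assay, at which 1 of the 3 values shown sits.

The compounds shown leave open whether a carboxylic acid, an amine or a chlorine on that aromatic carbon would move the number beyond the scatter. As far as these compounds go, a longer chain in place of methoxy also remains open.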